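The source may hold more compounds than are shown below. What is called first, only, known or untested is meant among the compounds shown, and "the series" means these compounds.

Series notes. In a functional assay on NCI-H23 cells (Homo sapiens) for inhibition, read by sulforhodamine B assay (a higher number here means a weaker inhibitor of growth, a lower number a stronger inhibitor of growth), compound 1 `O=C(CCC1=CCN(CCCc2ccc(Br)cc2)C1=O)NO` gives 2520 nM, compound 2 `Cc1cccc(CN2CC=C(CCC(=O)NO)C2=O)c1` gives 2500 nM, and compound 3 `O=C(CCC1=CCN(CCCc2ccc(Cl)cc2)C1=O)NO` gives 2520 nM. Compound 3 therefore stands level with compound 1 at the digits shown, the pair forming the highest of the three numbers, and its gap to compound 2 is within the scatter, so none of the three is separated from the others. Going by the values given here, the only measured step, no change at the digits printed from compound 1 to compound 3 (within the scatter), lies within the scatter. Compound 4 `CCOc1ccc(CCCN2CC=C(CCC(=O)NO)C2=O)cc1` differs from compound 3 by ethoxy in place of chloro on an aromatic carbon. Among the compounds with values here, no measured step exchanges a halogen for an ethoxy group, and the one step on this aromatic carbon gave no change, so no shift beyond the scatter is expected in this assay. Compound 4 is estimated at 2500 nM, between 1200 nM and 5500 nM. The expected step is a 1.0-fold lower number from compound 3 to compound 4 (0.00 log units; within the scatter).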

Compound 4, concentration for 50% growth inhibition: 2520 nM
The estimate for compound 4 lay 1.0-fold (0.00 log units) below the measured number; the measured number falls inside the stated range.
By their numbers in this assay, from the lowest: compounds 2, 1, 3 and 4 (each within the scatter of the next).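

In this assay, replacing a halogen of 1 heavy atom with ethoxy, which has 3 heavy atoms and 1 hydrogen-bond acceptor, gives no change at the digits printed from compound 3 to compound 4 (within the scatter) and no change at the digits printed from compound 1 to compound 4 (within the scatter). The earlier step compared only two halogens, whereas this aromatic carbon, para to a large group, now also takes an oxygen-linked group with no shift beyond the scatter. No evidence bears on this result. From the compounds shown here alone, whether an amine or a carboxylic acid on this carbon would separate from these groups remains open.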